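From 2-Chlorophenyl to 3-Hydroxyphenyl on a Shared Core

The source may report more compounds than this note shows. Statements on the series, on what has been measured and on what is new or still open speak of the compounds shown alone.

Three compounds have been measured in a physicochemical assay for solubility, read by spectrophotometry, in phosphate buffer, with a stated time of 18 h, at pH 7.4; a higher number here means a more soluble compound, a lower number a less soluble compound:

Compound 1, `CCc1ccc(-c2nc3c(c(C)nn3-c3ccccc3)c(-c3ccccc3[N+](=O)[O-])c2C#N)cc1`, gives 1200 nM.
Compound 2, `CCc1ccc(-c2nc3c(c(C)nn3-c3ccccc3)c(-c3ccccc3Cl)c2C#N)cc1`, gives 1700 nM.
Compound 3, `CCc1ccc(-c2nc3c(c(C)nn3-c3ccccc3)c(-c3ccccc3)c2C#N)cc1`, gives 47000 nM.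

Compound 2 stands second highest of the three. Its nearest neighbour is compound 1, with a 1.4-fold higher number from compound 1 to compound 2 (0.15 log units; within the scatter), and its furthest is compound 3, with a 28-fold higher number from compound 2 to compound 3 (1.44 log units; beyond the scatter).

Compound 4, `CCc1ccc(-c2nc3c(c(C)nn3-c3ccccc3)c(-c3cccc(O)c3)c2C#N)cc1`, differs from compound 2 in one place: 3-hydroxyphenyl in place of 2-chlorophenyl on an aromatic carbon.

Going by the values given here, two measured steps bear on this change. Both a 28-fold higher number from compound 2 to compound 3 (1.44 log units; beyond the scatter) and a 39-fold higher number from compound 1 to compound 3 (1.59 log units; beyond the scatter) show that losing the substituent on the phenyl ring is followed by a large rise in this assay. Among the compounds with values here, no measured step introduces a hydroxy group, so its own contribution is unknown. Compound 4 is therefore expected to show a large increase, a 24-fold higher number from compound 2 to compound 4 (1.37 log units; beyond the scatter). Compound 4 is estimated at 40000 nM, within a range from 12000 nM to 130000 nM.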

Compound 4, solubility: 18000 nM
Compound 4: middle estimate off by 2.2-fold (0.35 log units), on the high side; low and high end bracket the measured number.
By their numbers in this assay, from the lowest: compounds 1 and 2 (each within the scatter of the next); then compound 4; then compound 3.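

In this assay, 3-hydroxyphenyl in this place retains much of the rise seen with the unsubstituted phenyl ring, standing well clear of 2-chlorophenyl (an 11-fold higher number from compound 2 to compound 4 (1.02 log units; beyond the scatter)) and 2-nitrophenyl (a 15-fold higher number from compound 1 to compound 4 (1.18 log units; beyond the scatter)). A substituent on this phenyl ring therefore need not bring the number down as far as those two did. Even so, the hydroxy group gives up part of the rise (a 2.6-fold lower number from compound 3 to compound 4 (0.42 log units; beyond the scatter)).

Group and ring position change together in these compounds. 2-hydroxyphenyl or 3-chlorophenyl would be needed to separate them, and an amine or a carboxylic acid on this ring remains untested in the compounds shown. No evidence at hand explains these differences.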